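Swapping the left-hand aromatic group on a somatostatin receptor ligand

The source may report more compounds than this note shows. Statements on the series, on what has been measured and on what is new or still open speak of the compounds shown alone.

Measured compounds:
- compound 1 `COC(=O)c1cc(CC(C)CN2C[C@H]3CCCC[C@H]3[C@@H](C(=O)N3CCN(c4ccc([N+](=O)[O-])cc4)CC3)C2)cc(C(=O)OC)c1`: 107 nM
- compound 2 `COC(=O)c1cc(CC(C)CN2C[C@@H]3CCCC[C@@H]3[C@H](C(=O)N3CCN(c4ccc([N+](=O)[O-])cc4)CC3)C2)cc(C(=O)OC)c1`: 1.35 nM
- compound 3 `Cc1cn2cc(C[C@H](C)CN3C[C@@H]4CCCC[C@@H]4[C@H](C(=O)N4CCN(c5ccc(F)c(F)c5)CC4)C3)ccc2n1`: 107 nM

In an assay on isolated protein for binding affinity to somatostatin receptor type 3 (Homo sapiens) (on this read-out higher numbers stand for weaker binding and lower numbers for tighter binding), compound 1 gives 107 nM and compound 2 gives 1.35 nM. These two share all atoms and bonds and differ only in how three ring stereocentres are drawn, yet the change is a 79-fold lower number from compound 1 to compound 2 (1.90 log units; beyond the scatter); the only lead on why is the fact that one of compounds 1 and 2 is drawn with a defined configuration and the other without, at the place where they differ. Compound 3 gives 107 nM in this assay, level with compound 1 and, together with it, the highest of the three numbers, far from compound 2.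

Compound 4 `CCNc1ccc(C[C@H](C)CN2C[C@@H]3CCCC[C@@H]3[C@H](C(=O)N3CCN(c4ccc(F)c(F)c4)CC3)C2)cn1` keeps the core of compound 3 and differs only at the left-hand aromatic end: a group of 9 heavy atoms (7 carbon, 2 nitrogen; one six-membered aromatic ring with 1 hetero atom) in place of a group of 10 heavy atoms (8 carbon, 2 nitrogen; one five-membered aromatic ring with 2 hetero atoms, one six-membered aromatic ring with 1 hetero atom), on a saturated chain carbon, three bonds along the chain from an amine nitrogen in a ring. Within the data shown here, the one measured step concerns stereochemistry alone and says nothing about changing this aromatic group, so no size or direction can be read from it. The expected step of a 1.8-fold lower number from compound 3 to compound 4 (0.25 log units; within the scatter) is therefore set small, and compound 4 is estimated at 60 nM, with a range from 12 nM to 300 nM.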

Compound 4, dissociation constant: 28.8 nM
Beside the measured number, compound 4's estimate is 2.1-fold (0.32 log units) above it; measured number inside the range.
By their numbers in this assay, from the lowest: compound 2; then compound 4; then compounds 1 and 3 (each within the scatter of the next).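

Among these compounds, this is the only measured change at the left-hand aromatic end, on a saturated chain carbon, three bonds along the chain from an amine nitrogen in a ring. In this assay, putting 6-(ethylamino)pyridin-3-yl in place of the group with a five-membered and a six-membered aromatic ring gives a 3.7-fold lower number from compound 3 to compound 4 (0.57 log units; beyond the scatter), so this end can be exchanged and binding becomes modestly tighter rather than being lost. Nothing measured among these compounds gives a reason for this step.

The compounds shown leave open whether the ethylamino group or the change in aromatic rings accounts for the step; a plain amine or a methoxy group on the same six-membered aromatic ring would help separate the two. Also open, going by these compounds, is whether the same swap would give a similar step with the 4-nitrophenyl group of compound 2 at the other end.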